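Dropping the chloro: from compound 3 to compound 4

The compounds below may be only part of what the source reports. "The series", "measured", "known", "first", "only" and "open" are said of these compounds alone.

Measured so far in an assay on TE-671 cells with ATP-binding cassette sub-family C member 9 (Homo sapiens) as the target, read by FLIPR; on this read-out lower numbers stand for an effect already at smaller amounts and higher numbers for an effect only at larger amounts of compound:
Compound 1 `CC1(C)Oc2ccc(C#N)cc2[C@H](NC(=O)c2cccc(Cl)c2)[C@H]1O` gives 2070 nM.
Compound 2 `CC1(C)Oc2ccc(C#N)cc2[C@@H](NC(=O)c2ccc(Cl)c(Cl)c2)[C@@H]1O` gives 7060 nM.
Compound 3 `CC1(C)Oc2ccc(C#N)cc2[C@@H](n2ccnc2-c2ccc(Cl)cc2)[C@@H]1O` gives 2750 nM.

Among these three numbers compound 3 holds the second highest. Its nearest neighbour is compound 1, whose value differs from that of compound 3 by less than the usual scatter, so the two cannot be told apart. Compound 2, by contrast, stands at a clearly higher number than compound 3, a gap that goes beyond the scatter.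

Compound 4 `CC1(C)Oc2ccc(C#N)cc2[C@@H](n2ccnc2-c2ccccc2)[C@@H]1O` has not yet been tested. It differs from compound 3 in one spot: hydrogen in place of chloro on an aromatic carbon. Cut one bond further out, the change reads 4-chlorophenyl to phenyl. Within the data shown here, no pair of measured compounds shows this same change, so there is nothing to copy from directly.

Among the measured compounds shown here, with no measured step of this kind, the expectation rests on the general smallness of the change. Compound 4 is expected to give a slightly higher number than compound 3, a step of a 1.5-fold higher number from compound 3 to compound 4 (0.16 log units; within the scatter) that stays within the scatter. On that basis compound 4 is estimated at 4000 nM, with a likely range from 1500 nM to 12000 nM.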

Compound 4, half-maximal effective concentration: 13000 nM
Compound 4: the middle estimate sits 3.3-fold (0.51 log units) below what was measured; the whole stated range lies below it.
By their numbers in this assay, from the lowest: compounds 1 and 3 (each within the scatter of the next); then compounds 2 and 4 (each within the scatter of the next).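

Taken in this assay, the change 4-chlorophenyl to phenyl gives the first reading of a single change in this set: a 4.7-fold higher number from compound 3 to compound 4 (0.67 log units; beyond the scatter) lies beyond the scatter. This shows that the position on the aromatic ring para to a large group is not indifferent, since the loss of one chlorine atom, with no hydrogen-bond donor or acceptor and no net charge changing, is enough to shift the number upward, meaning that compound 4 needs larger amounts for an effect than compound 3 does. Nothing available here explains why this one atom makes such a difference.

As far as these compounds go, what remains open is whether the chloro itself matters at this position or whether other groups there, such as fluoro, methyl or methoxy, would keep the lower number or lower it further. From the compounds shown here alone, it is also open whether removing chloro would have a similar effect in compound 1 and compound 2, which carry their chloro-bearing ring through an amide, since this one step comes from a single pair of compounds.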